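A few compounds are considered here, and "the series" means these few. Any claim that something is new, unique, unknown or untested is made for them only; others in the source may bear on it.

Working notes on the series. Compound 1 `Nc1c(C2=NCCCN2)cnn1-c1cccc(Cl)c1` and compound 2 `Nc1c(C2=NCCCN2)cnn1-c1ccc(Cl)cc1` have the same atoms joined differently; the difference between the two cores is not broken down here. Compound 3 `Nc1c(C2=NCCCN2)cnn1-c1ccc(Br)cc1` differs from compound 2 by bromo in place of chloro on an aromatic carbon. Compound 4 `Nc1c(C2=NCCCN2)cnn1-c1cccc(Br)c1`, not yet measured, differs from compound 1 by bromo in place of chloro on an aromatic carbon. The change into compound 3 and the change into compound 4 are the same kind of change, occurring twice among these compounds, but the place is not the same word for word: in compound 3 the entering bromo stands para to a large group, in compound 4 it stands meta to a large group.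

In an ADME assay on Vero cells (Chlorocebus sabaeus) for cytotoxicity, read by CellTiter-Glo and ATP content, with a stated time of 72 h (on this read-out higher numbers stand for lower toxicity in this test and lower numbers for higher toxicity in this test), compound 1 gives > 500000 nM, which is a limit of the assay and not a number. In this assay compound 2 reaches only a limit, > 500000 nM. For compound 3 this assay again returns a limit, > 500000 nM. The measured step that the two limits leave unreadable from compound 2 to compound 3 therefore cannot be sized; behind this stands (the limit of > 500000 nM in this assay, at which 3 of the 3 values shown sit).

For compound 4 the step of a number no higher from compound 1 to compound 4 (the limit leaves the size open) in this assay is expected to be no more readable than the earlier one, an expectation resting on (the limit of > 500000 nM in this assay, at which 3 of the 3 values shown sit). Compound 4 is accordingly estimated at 500000 nM in this assay. Its expected range for compound 4 runs from 250000 nM to 1500000 nM, and the likeliest outcome for compound 4 is once more a limit rather than a number.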

Compound 4, half-maximal cytotoxic concentration: > 500000 nM
Compound 4: a limit, no number; the forecaster's own chance of this, stated with the estimate: 85%; the middle value sits exactly at the limit.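

The step from compound 1 to compound 4 in this assay cannot be read, because both compounds sit at a limit of the assay and not at a number: the limit of > 500000 nM in this assay, at which 4 of the 4 values shown sit.

The compounds shown leave open whether bromo in place of chloro on an aromatic carbon shifts the half-maximal cytotoxic concentration at all, and how compound 1, compound 2, compound 3 and compound 4 rank against one another.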